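The source may hold more compounds than are shown below. What is called first, only, known or untested is meant among the compounds shown, and "the series" means these compounds.

Measured so far in an assay on HeLa cells for displacement of a labelled ligand from adenosine receptor A3 (Homo sapiens), read by scintillation counting, with a stated time of 180 min, tested at 10 uM; a lower number here means less inhibition, a higher number more inhibition at the concentration tested (going by the name of the read-out):
compound 1 `COc1cccc2cc(C(=O)NCC(O)CO)c(=O)oc12` gives 1%
compound 2 `O=C(NCCCO)c1cc2cccc(O)c2oc1=O` gives 8%

Both values sit low, and the two lie within the usual scatter of each other, so no order can be read from them. Compound 3 `O=C(NCC(O)CO)c1cc2cccc(O)c2oc1=O` differs from compound 2 by hydroxy in place of hydrogen on a saturated chain carbon bound to two saturated chain carbons. Among the measured compounds shown here, no measured pair shows the effect of this change. Given that compound 1, which already carries the 2,3-dihydroxypropyl amide, gives 1%, the step from compound 2 to compound 3 is expected to be small, with no direction beyond the scatter, as a number 2 percentage points lower from compound 2 to compound 3 (within the scatter). Compound 3 is estimated at 6%, between 0% and 18%.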

Compound 3, a percentage reported as inhibition, at one concentration (the size of the read-out at that concentration, not a potency): 22%
Beside the measured number, compound 3's estimate is 16 percentage points below it, and the stated range ends below it.
By their numbers in this assay, from the lowest: compounds 1 and 2 (each within the scatter of the next); then compound 3.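

In this assay, going from 3-hydroxypropyl to 2,3-dihydroxypropyl gives a number 14 percentage points higher from compound 2 to compound 3 (beyond the scatter), so hydroxy in place of hydrogen on this saturated chain carbon can register beyond the scatter. With the 2,3-dihydroxypropyl chain held, hydrogen in place of methyl on the oxygen on the aromatic ring gives a number 21 percentage points higher from compound 1 to compound 3 (beyond the scatter), so the diol alone does not secure the higher number, as compound 1 stands at 1%. Nothing here gives a reason for either step. Going by these compounds, whether an amine, a carboxylic acid or a longer chain at this chain carbon would match compound 3 remains open. So does whether the hydroxy step holds with methyl kept on the ring oxygen.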